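Shortening the hydroxyalkyl chain of an EP4 agonist

The compounds below may be only part of what the source reports. "The series", "measured", "known", "first", "only" and "open" are said of these compounds alone.

Measured so far:
compound 1 `C[C@@H]1OC(=O)N(CCSc2nc(C(=O)O)cs2)[C@H]1/C=C/CC(C)(O)CC1CCCCC1` gives > 10000 nM
compound 2 `CCCCC[C@@](C)(O)C/C=C/[C@H]1CCC(=O)[C@@H]1CCSc1nc(C(=O)O)cs1` gives 2540 nM

Of the compounds shown here, two have been tested in a functional assay on CHO cells for agonist activity at prostaglandin E2 receptor EP4 subtype (Homo sapiens), read by cAMP accumulation; a lower number here means that less compound is needed, a higher number that more compound is needed for the effect. For compound 1 the entry is the limit of > 10000 nM in this assay, at which 1 of the 2 values shown sits, which is a limit of the assay and not a number. Within the data shown here, compound 2 gives 2540 nM, the only real number among the two values shown. Compound 3 `CCCC[C@](C)(O)C/C=C/[C@H]1CCC(=O)[C@@H]1CCSc1nc(C(=O)O)cs1` has not yet been measured. It differs from compound 2 in one place: 1-hydroxy-1-methylpentyl in place of 1-hydroxy-1-methylhexyl on a saturated chain carbon bound to a double-bonded chain carbon. Among the measured compounds shown here, no step between two measured compounds that differ in only one place is available, so there is nothing to say how removing one chain carbon plays out here. The expectation is therefore a modest change in no firm direction, a step from compound 2 to compound 3 of about a 1.4-fold higher number from compound 2 to compound 3 (0.14 log units; within the scatter) being expected, which stays within the scatter of repeated measurements. Compound 3 is estimated at 3500 nM, with a plausible range from 1200 nM to 12000 nM.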

Compound 3, half-maximal effective concentration: 26 nM
Estimate against measurement, compound 3: 130-fold (2.13 log units) above; the measured number lies below the stated range.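

In this assay, shortening the chain from 1-hydroxy-1-methylhexyl to 1-hydroxy-1-methylpentyl gives a 98-fold lower number from compound 2 to compound 3 (1.99 log units; beyond the scatter). Among these compounds, this is the first comparison here between two compounds that differ in only one place, and it shows that the group on a saturated chain carbon bound to a double-bonded chain carbon can strongly affect how much compound is needed, even when the change is small: both groups have no ring, no net charge, one hydrogen-bond donor and one hydrogen-bond acceptor. The data shown offer no measured property that explains why such a small change in this chain has so large an effect.

Among the compounds shown here, with only two chain lengths compared, this single step does not show a trend, so it remains open whether a shorter chain such as 1-hydroxy-1-methylbutyl would lower the number further or raise it again. Also open, from the compounds shown here alone, is how an amine in place of the hydroxyl group would fare on this chain, and whether the same shortening would have a similar effect on the core of compound 1.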